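Removing a Methyl on a Nucleoside Core

The source may report more compounds than this note shows. Statements on the series, on what has been measured and on what is new or still open speak of the compounds shown alone.

compound 1, `Cc1nsc2c1ncn2[C@H]1C[C@H](O)[C@@H](CO)O1`: > 100000 nM
compound 2, `CSc1nc2c(C)nsc2n1[C@H]1C[C@H](O)[C@@H](CO)O1`: > 100000 nM

In a functional assay on L1210 cells (Mus musculus) for antiproliferative activity (a lower number here means a stronger inhibitor, a higher number a weaker inhibitor), compound 1 gives only a limit, > 100000 nM. In this assay compound 2 likewise gives only a limit, > 100000 nM. The step that the two limits leave unreadable from compound 1 to compound 2 cannot be sized, as both values sit at the limit of > 100000 nM in this assay, at which 2 of the 2 values shown sit. Compound 3, `CSc1nc2cnsc2n1[C@H]1C[C@H](O)[C@@H](CO)O1`, differs from compound 2 by hydrogen in place of methyl on an aromatic carbon. Among the measured compounds shown here, no measured step tells what the loss of the methyl does, and the single measured step gives no size. Compound 3 is therefore expected to stay at the limit, with an estimated step of a number no higher from compound 2 to compound 3 (the limit leaves the size open). The estimate for compound 3 is 100000 nM, expected to lie between 30000 nM and 300000 nM.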

Compound 3, half-maximal inhibitory concentration: > 100000 nM
Compound 3 was reported as a limit; the forecaster's own chance of this, stated with the estimate: 85%; the middle value lies on the limit itself.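

Among the compounds shown here, compound 2 and compound 3 both sit at a limit, so no step between them can be read: the limit of > 100000 nM in this assay, at which 3 of the 3 values shown sit. The compounds shown leave open what the methyl or the methylsulfanyl does to activity in this assay.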